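Methyl on the triple bond of compound 3

The compounds below may be only part of what the source reports. "The series", "measured", "known", "first", "only" and "open" are said of these compounds alone.

In a functional assay on MIA PaCa-2 cells (Homo sapiens) for antiproliferative activity (a higher number here means that more compound is needed for the effect, a lower number that less compound is needed), compound 3 `C#CC(=O)Nc1cccc2c1cc(C)n2-c1nc2c(c(NCc3ccccc3)n1)COCC2` gives 78.7 nM, the lowest number of the three measured, against compound 2 `CC#CCNC(=O)c1cccc2c1cc(C)n2-c1nc2c(c(NCc3ccccc3)n1)COCC2` at 524 nM and compound 1 `C#CCNC(=O)c1cccc2c1cc(C)n2-c1nc2c(c(NCc3ccccc3)n1)COCC2` at 1080 nM. Compound 4 `CC#CC(=O)Nc1cccc2c1cc(C)n2-c1nc2c(c(NCc3ccccc3)n1)COCC2` differs from compound 3 by methyl in place of hydrogen on a triple-bonded carbon. One measured step shows this same change, a 2.1-fold lower number from compound 1 to compound 2 (0.31 log units; beyond the scatter), but in a propargylcarbamoyl chain rather than an (ethynylcarbonyl)amino group. The steps between those two groups are larger, a 14-fold lower number from compound 1 to compound 3 (1.14 log units; beyond the scatter) and a 6.7-fold lower number from compound 2 to compound 3 (0.82 log units; beyond the scatter), so this single precedent transfers only loosely. In this assay, a small step in the same direction is expected, possibly none beyond the scatter. The expected change is a 1.2-fold lower number from compound 3 to compound 4 (0.08 log units; within the scatter). The estimate for compound 4 is 65 nM, with an expected range of 18 nM to 240 nM.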

Compound 4, half-maximal effective concentration: 600 nM
Estimate against measurement, compound 4: 9.2-fold (0.97 log units) below, and the stated range ends below it.
By their numbers in this assay, from the lowest: compound 3; then compounds 2, 4 and 1 (each within the scatter of the next, the first and the last beyond it).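

In this assay, methyl in place of hydrogen on the triple-bonded carbon of the (ethynylcarbonyl)amino group gives a 7.6-fold higher number from compound 3 to compound 4 (0.88 log units; beyond the scatter), so the low number of compound 3 depends on that terminal hydrogen. The advantage of this group over the propargylcarbamoyl chains is then gone: a 1.1-fold higher number from compound 2 to compound 4 (0.06 log units; within the scatter) and a 1.8-fold lower number from compound 1 to compound 4 (0.26 log units; within the scatter) both stay within the scatter. The effect of this methyl therefore does not carry from one chain to the other: the same change on two cores in this assay, a 2.1-fold lower number (0.31 log units; beyond the scatter) from compound 1 to compound 2 and a 7.6-fold higher number (0.88 log units; beyond the scatter) from compound 3 to compound 4, 16-fold (1.20 log units) apart, beyond the scatter of two such steps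

Open, on these data alone, is whether the triple bond itself is required, as a prop-2-enoyl or propanoyl amide would show. Also open, as far as these compounds go, is whether a dimethylaminomethyl group on the triple-bonded carbon behaves like methyl.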